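Chloro for trifluoromethoxy: cytotoxicity expected to stay beyond reach

The source may hold more compounds than are shown below. What is called first, only, known or untested is meant among the compounds shown, and "the series" means these compounds.

Of the compounds shown here, two sharing one core have been tested in an ADME assay on MRC5 cells (Homo sapiens) for cytotoxicity, read by resazurin assay, with a stated time of 72 h; on this read-out lower numbers stand for stronger inhibition and higher numbers for weaker inhibition. Compound 1 `CC1(CNc2ccc(Cl)cc2)CCn2cc([N+](=O)[O-])nc2O1` gives >= 40000 nM, which is a limit rather than a number. Compound 2 `CN(CC1(C)CCn2cc([N+](=O)[O-])nc2O1)c1ccc(OC(F)(F)F)cc1` likewise gives >= 40000 nM, again a limit. Compound 2 therefore stands at the limit of >= 40000 nM in this assay, at which 2 of the 2 values shown sit, with no numbered value to rank it against. Compound 3 `CN(CC1(C)CCn2cc([N+](=O)[O-])nc2O1)c1ccc(Cl)cc1` differs from compound 2 by chloro in place of trifluoromethoxy on an aromatic carbon. Going by the values given here, no measured pair shows this change, so in this assay no step beyond the usual scatter is expected; the expected step is a number no higher from compound 2 to compound 3 (the limit leaves the size open). Compound 3 is estimated at 40000 nM, between 30000 nM and 60000 nM.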

Compound 3, half-maximal inhibitory concentration: >= 40000 nM
Compound 3 gave a limit, no number; the forecaster's own chance of this, stated with the estimate: 85%; the middle value lies on the limit itself.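

Going by these compounds alone, compound 3, like compound 1 and compound 2, gives only a limit and not a number, so no step to compound 3 can be read. The compounds shown leave open whether either change affects cytotoxicity at all.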